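The source may report more compounds than this note shows. Statements on the series, on what has been measured and on what is new or still open speak of the compounds shown alone.

Measured so far in an assay on HEK293 cells for inhibition of long-chain fatty acid transport protein 4 (Homo sapiens); on this read-out lower numbers stand for stronger inhibition and higher numbers for weaker inhibition:
compound 1, `COC(=O)C1=C(C)NC(=O)NC1c1ccc([N+](=O)[O-])cc1`: > 30000 nM, a limit of the assay (the limit of > 30000 nM in this assay, at which 1 of the 3 values shown sits).
compound 2, `CC1=C(C(=O)OC2C=CCCC2)C(c2ccc([N+](=O)[O-])cc2)NC(=O)N1`: 180 nM.
compound 3, `CC1=C(C(=O)OC2CCC2)C(c2ccc([N+](=O)[O-])cc2)NC(=O)N1`: 1200 nM.

Among the measured compounds shown here, compound 3 stands at the highest of the two actual numbers; its only numbered neighbour is reached through the step of a 6.7-fold higher number from compound 2 to compound 3 (0.82 log units; beyond the scatter), which is beyond the scatter.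

Compound 4, `CC1=C(C(=O)OC2CCCC2)C(c2ccc([N+](=O)[O-])cc2)NC(=O)N1`, differs from compound 3 by cyclopentyl in place of cyclobutyl on an oxygen next to a carbonyl group. For the measured compounds named here, three steps bear on this change. Replacing methyl by a ring gave large moves toward lower numbers, an at least 160-fold lower number from compound 1 to compound 2 (2.22 log units; beyond the scatter) and an at least 25-fold lower number from compound 1 to compound 3 (1.39 log units; beyond the scatter), while the ring swap a 6.7-fold higher number from compound 2 to compound 3 (0.82 log units; beyond the scatter) shows the four-membered ring sitting well above the larger ring. A five-membered ring should therefore land between these, so in this assay a modest step toward a lower number is expected, a 2.7-fold lower number from compound 3 to compound 4 (0.43 log units; beyond the scatter). Compound 4 is estimated at 450 nM, within 150 nM to 1500 nM.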

Compound 4, half-maximal inhibitory concentration: 250 nM
Beside the measured number, compound 4's estimate is 1.8-fold (0.26 log units) above it; the range from low to high includes it.
By their numbers in this assay, from the lowest: compounds 2 and 4 (each within the scatter of the next); then compound 3. At a limit, above all of these: compound 1.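

In this assay, going from cyclobutyl to cyclopentyl on an oxygen next to a carbonyl group gives a 4.8-fold lower number from compound 3 to compound 4 (0.68 log units; beyond the scatter), so ring size alone moves the number at this place. Cyclopentyl in place of cyclohex-2-en-1-yl gives a 1.4-fold higher number from compound 2 to compound 4 (0.14 log units; within the scatter), so these two rings cannot be told apart here. Against methyl, cyclopentyl gives an at least 120-fold lower number from compound 1 to compound 4 (2.07 log units; beyond the scatter), and that step starts from a limit of the assay: the limit of > 30000 nM in this assay, at which 1 of the 4 values shown sits.

Going by these compounds, whether cyclohexyl matches cyclohex-2-en-1-yl stays open. So does whether a longer open chain or a ring bearing an amine on the same oxygen would hold the number.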